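Tert-butyl for ethyl on the outer ring of compound 2

The source may report more compounds than this note shows. Statements on the series, on what has been measured and on what is new or still open speak of the compounds shown alone.

Compound 2 `CCc1ccc(-c2ccc(N(C[C@@H](N)[C@@H](C)CC)C(=O)[C@@H]3C[C@H]3c3ccccc3)cc2)cc1` carries the higher of the two numbers measured in a functional assay for agonist activity at G protein-coupled receptor 88 (Homo sapiens), read by HTRF and cAMP accumulation; a lower number here means that less compound is needed, a higher number that more compound is needed for the effect: compound 2 gives 44 nM, while compound 1 `CC[C@@H](C)[C@H](N)CN(C(=O)[C@@H]1C[C@H]1c1ccccc1)c1ccc(-c2ccccc2)cc1` gives 1.4 nM in this assay. Compound 3 `CC[C@H](C)[C@H](N)CN(C(=O)[C@@H]1C[C@H]1c1ccccc1)c1ccc(-c2ccc(C(C)(C)C)cc2)cc1` is compound 2 with tert-butyl in place of ethyl on an aromatic carbon, on an aromatic carbon of a six-membered aromatic ring of carbon only, para to a large group. Among the measured compounds shown here, no step between measured compounds isolates this change. Compound 1 stands far below compound 2, so a further rise for compound 3 seems more likely than a fall, and the step from compound 2 to compound 3 is estimated at a 2.7-fold higher number from compound 2 to compound 3 (0.44 log units; beyond the scatter). Compound 3 is expected at 120 nM, between 40 nM and 350 nM.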

Compound 3, half-maximal effective concentration: 750 nM
Beside the measured number, compound 3's estimate is 6.3-fold (0.80 log units) below it, and the stated range ends below it.
By their numbers in this assay, from the lowest: compound 1; then compound 2; then compound 3.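

Among the compounds shown here, this is the first single-place step, and it shows that this aromatic carbon is sensitive to the group it carries: in this assay, tert-butyl in place of ethyl gives a 17-fold higher number from compound 2 to compound 3 (1.23 log units; beyond the scatter). Nothing at hand bears on the cause of this step.

Open, on these data alone, is whether the number follows the carbon count of the group or its branching at this position. Isopropyl or a straight butyl chain would separate the two, and methoxy or an amine here would extend the comparison beyond hydrocarbon groups.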